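The source may hold more compounds than are shown below. What is called first, only, known or untested is meant among the compounds shown, and "the series" means these compounds.

Compound 3 `COCCNc1nc(C)c(-c2nc3c(C)nccc3s2)c(N[C@@H]2C[C@H](C(C)(C)O)[C@@H](O)[C@H]2O)n1` stands lowest of the two numbers obtained in an ADME assay on cells (Homo sapiens) for inhibition, read by scintillation proximity assay and thymidine incorporation, with a stated time of 3 days; on this read-out lower numbers stand for higher toxicity in this test and higher numbers for lower toxicity in this test: compound 3 gives 7000 nM, whereas compound 1 `Cc1nc(NCC2CC2)nc(N[C@@H]2C[C@H](C(C)(C)O)[C@@H](O)[C@H]2O)c1-c1nc2c(C)nccc2s1` gives 25000 nM. Compound 2 `Cc1nc(N[C@H](C)C2CC2)nc(N[C@@H]2C[C@H](C(C)(C)O)[C@@H](O)[C@H]2O)c1-c1nc2c(C)nccc2s1` in this assay yields only a limit, > 25000 nM. Compound 4 `COC[C@@H](C)Nc1nc(C)c(-c2nc3c(C)nccc3s2)c(N[C@@H]2C[C@H](C(C)(C)O)[C@@H](O)[C@H]2O)n1` differs from compound 3 by methyl in place of hydrogen on a saturated chain carbon bound to a nitrogen on an aromatic ring and a saturated chain carbon. Within the data shown here, the one measured step of the same kind is a number no lower from compound 1 to compound 2 (the limit leaves the size open), which leaves its size open. The other two steps, a 3.6-fold lower number from compound 1 to compound 3 (0.55 log units; beyond the scatter) and an at least 3.5-fold lower number from compound 2 to compound 3 (0.55 log units; beyond the scatter), exchange the whole chain and so bear less directly on this change. On that basis compound 4 is expected to give a number no lower than compound 3, the estimated step being a 1.4-fold higher number from compound 3 to compound 4 (0.15 log units; within the scatter). Compound 4 is accordingly estimated at 10000 nM, with an expected range from 4000 nM to 25000 nM.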

Compound 4, half-maximal cytotoxic concentration: 25000 nM
Estimate against measurement, compound 4: 2.5-fold (0.40 log units) below, and the stated range covers the measured number.
By their numbers in this assay, from the lowest: compound 3; then compounds 1 and 4 (each within the scatter of the next).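

In this assay, methyl in place of hydrogen on this saturated chain carbon now has a readable size, a 3.6-fold higher number from compound 3 to compound 4 (0.55 log units; beyond the scatter), which the earlier step ending in a limit could not give. Exchanging the whole chain gives no change at the digits printed from compound 1 to compound 4 (within the scatter), so the 1-(methoxymethyl)ethyl and cyclopropylmethyl chains are not told apart here. The remaining step is a number no higher from compound 2 to compound 4 (the limit leaves the size open) and its size cannot be read, and the methyl change cannot be compared between the two cores: the same change on two cores in this assay, a number no lower (the limit leaves the size open) from compound 1 to compound 2 and a 3.6-fold higher number (0.55 log units; beyond the scatter) from compound 3 to compound 4; the limit leaves it open whether they differ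

From the compounds shown here alone, how an ethyl group or a hydroxymethyl group in place of this methyl would read in this assay stays open.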